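Replacing the phenyl on a carbonyl carbon with nonyl

The source may report more compounds than this note shows. Statements on the series, on what has been measured and on what is new or still open speak of the compounds shown alone.

Measured in this series:
compound 1 `CC(C)(C)N(NC(=O)c1ccccc1)C(=O)c1ccccc1F`: 309 nM
compound 2 `Cc1cc(C)cc(C(=O)N(NC(=O)c2ccccc2)C(C)(C)C)c1`: 69.2 nM
compound 3 `CC(C)(C)N(NC(=O)c1ccccc1)C(=O)C1CCCCC1`: 46800 nM

In an assay on cells for agonist activity at ecdysone receptor (Bombyx mori), read by a luciferase reporter, with a stated time of 24 h (a lower number here means that less compound is needed, a higher number that more compound is needed for the effect), compound 2 gives the lowest of the three numbers; compound 1 sits a 4.5-fold lower number from compound 1 to compound 2 (0.65 log units; beyond the scatter) away, and compound 3 lies far above it, as a 680-fold higher number from compound 2 to compound 3 (2.83 log units; beyond the scatter) shows.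

Compound 4 `CCCCCCCCCC(=O)NN(C(=O)c1cc(C)cc(C)c1)C(C)(C)C` carries nonyl in place of phenyl on a carbonyl carbon. Going by the values given here, no measured step swaps an aromatic ring for a chain; the nearest are a 680-fold higher number from compound 2 to compound 3 (2.83 log units; beyond the scatter) and a 150-fold higher number from compound 1 to compound 3 (2.18 log units; beyond the scatter), both large losses when cyclohexyl replaces an aromatic ring on a carbonyl carbon. Whether a nonyl chain behaves like cyclohexyl is not shown, but a large increase is expected, about a 430-fold higher number from compound 2 to compound 4 (2.64 log units; beyond the scatter). Compound 4 is therefore estimated at 30000 nM (range 4000 nM to 200000 nM).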

Compound 4, half-maximal effective concentration: 1550 nM
Compound 4: the middle estimate sits 19-fold (1.29 log units) above what was measured; the measured number lies below the stated range.
By their numbers in this assay, from the lowest: compound 2; then compound 1; then compound 4; then compound 3.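

In this assay, the phenyl on this carbonyl carbon can give way to nonyl at a clear cost, a 22-fold higher number from compound 2 to compound 4 (1.35 log units; beyond the scatter), yet compound 4 still gives a finite reading, so an aromatic ring here is not essential for a response. Going by these compounds alone, the earlier steps changed only the group on the other carbonyl carbon, so this is the first reading of this position. Nothing on hand accounts for the loss.

On these data alone, whether a butyl chain or a longer chain would do better here remains open. So does whether a pyridine ring would retain the response of compound 2.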